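A few compounds are considered here, and "the series" means these few. Any claim that something is new, unique, unknown or untested is made for them only; others in the source may bear on it.

Compound 2 `O=C(Nc1nc2ccc(C(F)(F)F)cc2s1)C1CC1` is the starting point of this step. In an ADME assay on H9c2 cells (Rattus norvegicus) for cytotoxicity (on this read-out lower numbers stand for stronger inhibition and higher numbers for weaker inhibition), compound 2 gives only a limit of the assay, > 50000 nM, and no number. Within the data shown here, its one measured neighbour is compound 1 `O=C(Nc1nc2ccc(OC(F)(F)F)cc2s1)C1CC1`, which in this assay gives 5000 nM. Among the measured compounds shown here, the single measured step, an at least 10-fold higher number from compound 1 to compound 2 (1.00 log units; beyond the scatter), is the only comparison available, and compound 2 sits at the limit of > 50000 nM in this assay, at which 1 of the 2 values shown sits.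

Compound 3 `CC(C)(F)C(=O)Nc1nc2ccc(C(F)(F)F)cc2s1` has not yet been measured. It differs from compound 2 in one place: 1-fluoro-1-methylethyl in place of cyclopropyl on a carbonyl carbon. The measured step concerns a group on an aromatic carbon rather than the carbonyl side, and nothing measured bears on the present change. In this assay no step beyond the scatter is therefore expected from this exchange. The estimated step of a number no higher from compound 2 to compound 3 (the limit leaves the size open) would keep compound 3 at the edge of what the assay can report. Compound 3 is expected to give about 50000 nM in this assay, with a range from 20000 nM to 50000 nM, and most likely only a limit again.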

Compound 3, half-maximal inhibitory concentration: > 50000 nM
Compound 3 was reported as a limit; the forecaster's own chance of this, stated with the estimate: 75%; the middle value lies on the limit itself.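

In this assay compound 2 and compound 3 both give only a limit of the assay and no number, so no step can be read between them: the limit of > 50000 nM in this assay, at which 2 of the 3 values shown sit. The compounds shown leave open how far either true value lies past that limit, and whether 1-fluoro-1-methylethyl in place of cyclopropyl on a carbonyl carbon changes the result in this assay at all.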